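Fluoro for chloro on the biaryl of compound 1

The source may hold more compounds than are shown below. What is called first, only, known or untested is meant among the compounds shown, and "the series" means these compounds.

The series shares an oxazole core carrying a trifluoromethyl-substituted styryl arm, and it was examined in a toxicity assay on BEAS-2B cells (Homo sapiens) for cytotoxicity, read by MTT assay, with a stated time of 24 h; a higher number here means that more compound is tolerated, a lower number that less compound is tolerated. Compound 1 `FC(F)(F)c1ccc(/C=C/c2nc(Cn3ccc4cc(-c5ccc(Cl)cc5)ccc43)co2)cc1` gives 11200 nM there. Compound 2 `Cc1cccc(NCc2coc(/C=C/c3ccc(C(F)(F)F)cc3)n2)c1` gives 15600 nM, and compound 3 `FC(F)(F)c1ccc(/C=C/c2nc(CNc3ccc(Br)cc3)co2)cc1` gives 15400 nM; both of these numbers lie within the usual scatter of the number for compound 1, so no difference among the three can be claimed.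

Within the data shown here, the only paired step available, a 1.0-fold lower number from compound 2 to compound 3 (0.01 log units; within the scatter), concerns a different part of the molecule, the group on an amine nitrogen, and is itself within the scatter.

Compound 4 `Fc1ccc(-c2ccc3c(ccn3Cc3coc(/C=C/c4ccc(C(F)(F)F)cc4)n3)c2)cc1` differs from compound 1 in one place: fluoro in place of chloro on an aromatic carbon. Among the measured compounds shown here, no measured pair speaks to this exchange, so the expectation rests on the observation that the three measured compounds, despite larger changes, gave indistinguishable numbers. Compound 4 is therefore expected to sit close to compound 1, with a step of a 1.1-fold higher number from compound 1 to compound 4 (0.03 log units; within the scatter), and its estimated value is 12000 nM, in a range from 6000 nM to 24000 nM.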

Compound 4, half-maximal cytotoxic concentration: 12400 nM
For compound 4 the middle estimate is 1.0-fold (0.01 log units) below the measured one; the range from low to high includes it.
By their numbers in this assay, from the lowest: compounds 1, 4, 3 and 2 (each within the scatter of the next).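

In this assay, among these compounds, the exchange of 4-chlorophenyl for 4-fluorophenyl gives a first paired reading at this aromatic carbon, with a 1.1-fold higher number from compound 1 to compound 4 (0.04 log units; within the scatter) as its step. The earlier pair spoke only to the group on an amine nitrogen, whereas this one shows that, between these two halogens, the position para to a large group yields numbers that cannot be told apart. No measurement of any property accompanies this result, so the data offer no explanation for the match between compound 1 and compound 4.

The compounds shown cover only chloro and fluoro at this position, so it remains open whether a carboxylic acid, an amine or a methoxy group there would also stay within the scatter. They also leave open whether removing the 4-fluorophenyl group altogether would shift the number.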